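Aryl amide swap from compound 3 to compound 4

The compounds below may be only part of what the source reports. "The series", "measured", "known", "first", "only" and "open" are said of these compounds alone.

Of the compounds shown here, three sharing one core have been measured in a functional assay on SiHa cells (Homo sapiens) for inhibition, read by CCK-8 assay, with a stated time of 72 h, tested at 1 uM (a lower number here means less inhibition of growth, a higher number more inhibition of growth at the concentration tested), and they differ only in the aryl group on an amide-type nitrogen. Compound 1 `CN(C)C(=O)c1cc2cnc(Nc3ccc(NC(=O)C4(C(=O)Nc5cccc(O)c5)CC4)cc3)nc2n1C1CCCC1` gives -19.8%. Compound 2 `CN(C)C(=O)c1cc2cnc(Nc3ccc(NC(=O)C4(C(=O)Nc5ccccc5F)CC4)cc3)nc2n1C1CCCC1` gives 63.4%. Compound 3 `CN(C)C(=O)c1cc2cnc(Nc3ccc(NC(=O)C4(C(=O)Nc5ccc(Br)cc5)CC4)cc3)nc2n1C1CCCC1` gives 23.2%, which places it second of the three, with gaps beyond the scatter on both sides.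

The next structure is compound 4 `CN(C)C(=O)c1cc2cnc(Nc3ccc(NC(=O)C4(C(=O)Nc5ccc(Cl)c(C(F)(F)F)c5)CC4)cc3)nc2n1C1CCCC1`, with 4-chloro-3-(trifluoromethyl)phenyl in place of 4-bromophenyl on an amide-type nitrogen.

All three measured steps bear on this change, as they occur at the same place. They are a number 83.2 percentage points higher from compound 1 to compound 2 (beyond the scatter), a number 43 percentage points higher from compound 1 to compound 3 (beyond the scatter) and a number 40.2 percentage points lower from compound 2 to compound 3 (beyond the scatter). All are large, so this place is sensitive to the choice of aryl group. None of them involves the entering group, however, so they give no firm direction. Compound 4 carries halogen on this ring, as do compound 2 and compound 3, and both of those stand well clear of compound 1.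

The expected step is a number 8.8 percentage points higher from compound 3 to compound 4 (within the scatter), which is no clear move beyond the scatter, although a large step in either direction remains possible. For compound 4 the estimate is 32%, with an expected range of 5% to 65%.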

Compound 4, percent growth inhibition at one concentration: -11.2%
Estimate against measurement, compound 4: 43.2 percentage points above; the measured number lies below the stated range.
By their numbers in this assay, from the lowest: compounds 1 and 4 (each within the scatter of the next); then compound 3; then compound 2.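

In this assay a halogen on this aryl ring proves not to be enough for growth inhibition: 4-chloro-3-(trifluoromethyl)phenyl in place of 4-bromophenyl on the amide-type nitrogen gives a number 34.4 percentage points lower from compound 3 to compound 4 (beyond the scatter) and, against the 2-fluorophenyl group, the same replacement gives a number 74.6 percentage points lower from compound 2 to compound 4 (beyond the scatter) so the link between halogen and inhibition seen in compound 2 and compound 3 does not hold for compound 4. The series also now shows that two very different aryl groups can end up at the same low level, with a number 8.6 percentage points higher from compound 1 to compound 4 (within the scatter) and thus no separation between the 3-hydroxyphenyl group and a group of 11 heavy atoms carrying chlorine and three fluorines. No measurement shown here explains the drop at this position.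

Since compound 4 differs from compound 3 in both the halogen and the added trifluoromethyl, the compounds shown cannot assign the drop to either one, and a phenyl ring with a single chlorine or a single trifluoromethyl would separate the two. On these data alone, it also remains open how this nitrogen tolerates an aryl ring bearing an amine or a carboxylic acid, or a plain unsubstituted phenyl.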